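The source may report more compounds than this note shows. Statements on the series, on what has been measured and on what is new or still open speak of the compounds shown alone.

Measured so far:
Compound 1, `Fc1ccc(-c2csc(N/N=C/c3ccc(Cl)cc3Cl)n2)cc1`: 90.7%
Compound 2, `COc1ccc(-c2csc(N/N=C/c3ccc(Cl)cc3Cl)n2)cc1`: 65.5%

Both compounds share the same core and differ only in one group on an outer ring. In a functional assay, read by spectrophotometry, with a stated time of 15 min, tested at 20 ug/mL (a lower number here means a weaker effect, a higher number a stronger effect of the compound at the concentration tested), compound 1 gives 90.7%, while compound 2 gives 65.5%. Compound 2 thus stands lowest of the two numbers; its nearest neighbour is compound 1, and the step of a number 25.2 percentage points lower from compound 1 to compound 2 (beyond the scatter) lies beyond the scatter.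

Compound 3, `Clc1ccc(/C=N/Nc2nc(-c3ccccc3)cs2)c(Cl)c1`, has not yet been measured. Compared with compound 2 the change is hydrogen in place of methoxy on an aromatic carbon. Among the measured compounds shown here, only one measured step exists, a number 25.2 percentage points lower from compound 1 to compound 2 (beyond the scatter), and it describes an exchange of fluoro for methoxy rather than the removal of methoxy, so it bears on this question only loosely. Because compound 1 gives 90.7% and compound 2 gives 65.5%, a compound carrying neither group is expected to fall near or between these two numbers. The expected step is a number 9.5 percentage points higher from compound 2 to compound 3 (within the scatter), upward but uncertain. Compound 3 is therefore estimated at 75%, with a likely range from 50% to 95%.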

Compound 3, a percentage reported as inhibition, at one concentration (the size of the read-out at that concentration, not a potency): 76.6%
Estimate against measurement, compound 3: 1.6 percentage points below, and the stated range covers the measured number.
By their numbers in this assay, from the lowest: compound 2; then compound 3; then compound 1.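

Compound 3 carries a plain hydrogen on this aromatic carbon, para to a large group, and so gives the first reference point for judging each substituent separately. In this assay, the change from 4-methoxyphenyl to phenyl gives a number 11.1 percentage points higher from compound 2 to compound 3 (beyond the scatter), while replacing fluoro with hydrogen gives a number 14.1 percentage points lower from compound 1 to compound 3 (beyond the scatter), so the earlier gap now splits into two parts, and the two groups lie on opposite sides of hydrogen: methoxy goes with a lower inhibition reading and fluoro with a higher one, each by a step beyond the scatter. The data show only this ordering at a single test concentration, not a difference in potency, and no measurement shown here accounts for it.

Three substituents cannot show whether the ordering extends to other groups at this position, such as a chlorine atom, a methyl group, an amine or a carboxylic acid. As far as these compounds go, it also remains open whether fluoro or methoxy would give the same ordering elsewhere on this six-membered ring.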